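The source may report more compounds than this note shows. Statements on the series, on what has been measured and on what is new or still open speak of the compounds shown alone.

Working notes on the series.

Of the compounds shown here, two of the shared core have been measured in a functional assay on HCT-15 cells (Homo sapiens) for cytotoxicity, read by CCK-8 assay; a lower number here means a stronger inhibitor, a higher number a weaker inhibitor. Compound 1 `Oc1ccc(-c2cc(-c3cccs3)cc(-c3ccc(O)cc3)n2)cc1` gives only a limit of the assay, > 50000 nM, and this limit is where (the limit of > 50000 nM in this assay, at which 1 of the 2 values shown sits). Compound 2 `Oc1ccc(-c2cc(-c3ccsc3)cc(-c3cccc(O)c3)n2)cc1` gives a number in this assay, 1180 nM, and it is the only number shown in the set, so it stands alone with no measured step to compare against.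

Compound 3 `Oc1ccc(-c2cc(-c3ccsc3)cc(-c3ccc(O)cc3)n2)cc1` has not yet been measured in this assay. It carries the same atoms as compound 2 joined differently: 4-hydroxyphenyl in place of 3-hydroxyphenyl on an aromatic carbon, so that 4-hydroxyphenyl replaces 3-hydroxyphenyl on the aromatic carbon next to the ring nitrogen, and compound 3 then carries two 4-hydroxyphenyl groups as compound 1 does, with thiophen-3-yl in place of thiophen-2-yl on the core.

Among the compounds with values here, no measured step between neighbouring compounds exists here to set a size for this change. The step from compound 2 to compound 3 is expected to weaken inhibition beyond the scatter, an 8.5-fold higher number from compound 2 to compound 3 (0.93 log units; beyond the scatter), and the estimate rests on the limit of compound 1 > 50000 nM as the nearest comparison with the same two 4-hydroxyphenyl groups. For compound 3 the expected value in this assay is 10000 nM, within a range from 2000 nM to 50000 nM.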

Compound 3, half-maximal inhibitory concentration: 1040 nM
The estimate for compound 3 lay 9.6-fold (0.98 log units) above the measured number, outside the stated range (below it).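

In this assay, 4-hydroxyphenyl in place of 3-hydroxyphenyl on the aromatic carbon next to the ring nitrogen gives a 1.1-fold lower number from compound 2 to compound 3 (0.05 log units; within the scatter), so with thiophen-3-yl on the core, this pair does not separate the two hydroxyphenyl groups. Within the data shown here, the larger change in the set is thiophen-3-yl in place of thiophen-2-yl on an aromatic carbon, with the two 4-hydroxyphenyl groups held the same: an at least 48-fold lower number from compound 1 to compound 3 (1.68 log units; beyond the scatter) is the first step measured for that place, and it lies beyond the scatter. Compound 1 stands at a limit of the assay rather than at a number, so this step is bounded on one side only: the limit of > 50000 nM in this assay, at which 1 of the 3 values shown sits.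

Going by these compounds, whether the exchange of 3-hydroxyphenyl and 4-hydroxyphenyl would stay within the scatter with thiophen-2-yl on the core remains open, as this pair rests on thiophen-3-yl alone. Also open is how the read-out would respond to an amine or a methoxy group in place of the hydroxyl on either aryl group, since every compound shown carries hydroxyl groups there.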